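The source may report more compounds than this note shows. Statements on the series, on what has been measured and on what is new or still open speak of the compounds shown alone.

Measured compounds, each in a functional assay on HBL-100 cells (Homo sapiens) for inhibition, read by sulforhodamine B assay, with a stated time of 48 h; a lower number here means a stronger inhibitor of growth, a higher number a weaker inhibitor of growth:
Compound 1 `O=C(/C=C/C1CCCCC1)c1ccccc1` gives 18000 nM.
Compound 2 `O=C(/C=C/c1ccc(Cl)cc1Cl)c1ccccc1` gives 17000 nM.
Compound 3 `CCC(/C=C(\COC(C)=O)C(=O)c1ccccc1)CC` gives only a limit, > 100000 nM.

Compound 3 stands apart from the other two, since for compound 3 this assay reports no number, only the limit > 100000 nM; this is the limit of > 100000 nM in this assay, at which 1 of the 3 values shown sits. Compound 1 and compound 2 both give real numbers, and the two numbers lie within the usual scatter of each other, so no order between them can be read.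

The unmeasured compound is compound 4 `CC(=O)OC/C(=C\c1ccccc1Br)C(=O)c1ccccc1`. It is built from compound 3 by one change, (2-bromophenyl in place of pentan-3-yl on a double-bonded chain carbon bound to a double-bonded chain carbon); in words, 2-bromophenyl in place of pentan-3-yl on a double-bonded chain carbon bound to a double-bonded chain carbon. Among the compounds with values here, no step between measured compounds of this kind has been recorded, so the size of the step must be estimated. Compound 2, whose chain also ends in a ring, gives 17000 nM, and that guides the expectation. The step from compound 3 to compound 4 is expected to run toward stronger growth inhibition, an at least 3.3-fold lower number from compound 3 to compound 4 (0.52 log units; beyond the scatter), beyond the scatter. Compound 4 is accordingly expected to give 30000 nM, with a range from 8000 nM to 100000 nM.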

Compound 4, concentration for 50% growth inhibition: 22000 nM
Beside the measured number, compound 4's estimate is 1.4-fold (0.13 log units) above it, and the stated range covers the measured number.
By their numbers in this assay, from the lowest: compounds 2, 1 and 4 (each within the scatter of the next). At a limit, above all of these: compound 3.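

The change of pentan-3-yl to 2-bromophenyl on a double-bonded chain carbon bound to a double-bonded chain carbon gives an at least 4.5-fold lower number from compound 3 to compound 4 (0.65 log units; beyond the scatter) in this assay, so growth inhibition at this place does depend on the group it carries. Compound 3 gives only a limit, > 100000 nM. The step is therefore a lower bound and not a full size, because its starting point is not a number: the limit of > 100000 nM in this assay, at which 1 of the 4 values shown sits.

The change brings in an aromatic ring and a bromine together, so these compounds cannot say which of the two accounts for the step; a plain phenyl group at this place would separate them, and an amine on the ring would test a quite different kind of group. As far as these compounds go, compound 4 also differs from compound 1 and from compound 2 in more than one place, so no step can be read between them, and what the acetoxymethyl group contributes to growth inhibition stays open.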